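Amide Boronic Acids Against Ovarian Cancer Cells

The compounds below may be only part of what the source reports. "The series", "measured", "known", "first", "only" and "open" are said of these compounds alone.

Measured compounds:
compound 1 `O=C(CCc1cccc2c1B(O)OC2)NC1CCCCC1` gives > 100000 nM
compound 2 `Cc1ccc(NC(=O)CCc2cccc3c2B(O)OC3)cc1` gives 860 nM
compound 3 `O=C(CCc1cccc2c1B(O)OC2)Nc1cccc(I)c1` gives 630 nM

All three share one core and differ only in the group on the amide nitrogen. In a functional assay on SK-OV-3 cells (Homo sapiens) for antiproliferative activity, read by MTT assay, with a stated time of 72 h (on this read-out higher numbers stand for weaker inhibition and lower numbers for stronger inhibition), compound 1 carries a cyclohexyl group, and its value is a limit of the assay rather than a number (the limit of > 100000 nM in this assay, at which 1 of the 3 values shown sits). Compound 2 carries a 4-methylphenyl group and compound 3 a 3-iodophenyl group. Exchanging the cyclohexyl for either aromatic group brings a large step: an at least 110-fold lower number from compound 1 to compound 2 (2.06 log units; beyond the scatter) and an at least 150-fold lower number from compound 1 to compound 3 (2.20 log units; beyond the scatter). Between the two aromatic groups the difference is small, a 1.4-fold lower number from compound 2 to compound 3 (0.14 log units; within the scatter), so compound 3 has the lowest of the two numbers but cannot be set apart from compound 2.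

Compound 4 `O=C(CCc1cccc2c1B(O)OC2)Nc1cccc(-c2ccc(C(F)(F)F)cc2)c1` is not yet measured. It differs from compound 3 in one place: 4-(trifluoromethyl)phenyl in place of iodo on an aromatic carbon. Among the measured compounds shown here, none of the measured steps tests this kind of change; the steps seen only compare a saturated ring with aromatic groups on the amide nitrogen, and compound 4 keeps an aromatic group there. The expected step of a 1.1-fold higher number from compound 3 to compound 4 (0.05 log units; within the scatter) is therefore small, not beyond the scatter. Compound 4 is estimated at 700 nM, within a range from 150 nM to 4000 nM.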

Compound 4, half-maximal inhibitory concentration: 500 nM
Beside the measured number, compound 4's estimate is 1.4-fold (0.15 log units) above it; the range from low to high includes it.
By their numbers in this assay, from the lowest: compounds 4, 3 and 2 (each within the scatter of the next). At a limit, above all of these: compound 1.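

The earlier compounds shown here only exchanged the whole group on the amide nitrogen, whereas here the aromatic group on that nitrogen stays and one of its carbons carries something else; in this assay this change reads as a 1.3-fold lower number from compound 3 to compound 4 (0.10 log units; within the scatter). This aromatic carbon can therefore carry either iodo, with 1 heavy atom, or 4-(trifluoromethyl)phenyl, with 10 heavy atoms and an additional six-membered aromatic ring, and the two compounds cannot be told apart on this read-out, even though the group entering is far larger by this count. Nothing among the available measurements bears on what lies behind this result.

Going by these compounds, how an amine, a carboxylic acid or a longer chain on this same aromatic carbon would read stays open, so the result covers only iodo and 4-(trifluoromethyl)phenyl, not every group at this place. Also open, on these data alone, is whether a plain phenyl, without the trifluoromethyl, would read like compound 4, since the added ring and the trifluoromethyl enter together and their shares cannot be separated.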